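From benzyl to 3-chloro-4-fluorobenzyl in compound 2

The compounds below may be only part of what the source reports. "The series", "measured", "known", "first", "only" and "open" are said of these compounds alone.

In an in vivo ADME assay on the whole organism for pharmacokinetics, with Rattus norvegicus as the target, at a dose of 2 mg/kg by the intravenous route (on this read-out lower numbers stand for slow clearance and higher numbers for fast clearance), compound 1 (`CC(C)(C)CCN1C(=O)C(C2=CS(=O)(=O)c3cc(NS(C)(=O)=O)ccc3N2)=C(O)[C@@H]1C(C)(C)C`) gives > 100 mL/min/kg, which is a limit of the assay and not a number. For the measured compounds named here, compound 2 (`CC(C)(C)[C@H]1C(O)=C(C2=CS(=O)(=O)c3cc(NS(C)(=O)=O)ccc3N2)C(=O)N1Cc1ccccc1`) gives 144 mL/min/kg, the only true number so far. Compound 3 (`CC(C)(C)[C@H]1C(O)=C(C2=CS(=O)(=O)c3cc(NS(C)(=O)=O)ccc3N2)C(=O)N1Cc1ccc(F)c(Cl)c1`) carries 3-chloro-4-fluorophenyl in place of the phenyl of compound 2: 3-chloro-4-fluorophenyl in place of phenyl on a saturated chain carbon bound to an amide-type nitrogen in a ring. Going by the values given here, the one measured step, a step that the limit leaves unreadable from compound 1 to compound 2, changes the same place but has no readable size. No shift beyond the usual scatter is therefore expected, and the estimated step is a 1.2-fold lower number from compound 2 to compound 3 (0.06 log units; within the scatter). Compound 3 is expected at 125 mL/min/kg, with an estimated range of 65 mL/min/kg to 220 mL/min/kg.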

Compound 3, clearance: 86 mL/min/kg
The estimate for compound 3 lay 1.5-fold (0.16 log units) above the measured number; the range from low to high includes it.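

For the compounds shown here, at this place, on a saturated chain carbon bound to an amide-type nitrogen in a ring, 3-chloro-4-fluorophenyl gives the first step of readable size: a 1.7-fold lower number from compound 2 to compound 3 (0.22 log units; within the scatter). Chlorine and fluorine on the phenyl therefore do not clearly separate the two compounds in this assay. Against neopentyl, the only reading is a floor, an at least 1.1-fold lower number from compound 1 to compound 3 (0.06 log units; that floor lies within the scatter). The value of compound 1 is a limit and not a number, so its step to compound 2 cannot be read: the limit of > 100 mL/min/kg in this assay, at which 1 of the 3 values shown sits.

Still open, as far as these compounds go, is whether chlorine or fluorine alone would shift clearance. Also open, from the compounds shown here alone, is what a group carrying an amine or a carboxylic acid would give at this place.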